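A few compounds are considered here, and "the series" means these few. Any claim that something is new, unique, unknown or untested is made for them only; others in the source may bear on it.

Working notes on the series in a functional assay on the whole organism with Mus musculus as the target; on this read-out lower numbers stand for an effect already at smaller amounts and higher numbers for an effect only at larger amounts of compound.

Of the compounds shown here, three of the shared core have been measured. Compound 1 `O=C(/C=C1\CCc2c1ccc(F)c2F)NC1CC1` gives 62 mg/kg in this assay. Compound 2 `NC(=O)/C=C1\CCc2c(F)cc(F)cc21` gives 69 mg/kg. Compound 3 `NC(=O)/C=C1\CCc2ccc(F)cc21` gives 56 mg/kg. All three numbers lie within the scatter of one another, so no order among them can be read from these data.

For the measured compounds named here, the single step between measured compounds that differ in one place, hydrogen in place of fluoro on an aromatic carbon, is a 1.2-fold lower number from compound 2 to compound 3 (0.09 log units; within the scatter). It concerns the aromatic ring only.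

The next compound is compound 4 `CNC(=O)/C=C1\CCc2c(F)cc(F)cc21`, to be measured in this assay. It differs from compound 2 as follows: methyl in place of hydrogen on an amide-type nitrogen. Going by the values given here, no measured step touches the amide nitrogen; the only step available, a 1.2-fold lower number from compound 2 to compound 3 (0.09 log units; within the scatter), sits on the aromatic ring and does not bear on methylcarbamoyl in place of carbamoyl. The expectation therefore rests on compound 2 alone, with no basis for a shift beyond the scatter in either direction.

For compound 4 the estimate is 69 mg/kg, with a range from 35 mg/kg to 140 mg/kg. The step this estimate means, no change at the digits printed from compound 2 to compound 4 (within the scatter), is expected to stay within the scatter.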

Compound 4, dose for half-maximal effect: 45 mg/kg
Compound 4: middle estimate off by 1.5-fold (0.19 log units), on the high side, and the stated range covers the measured number.
By their numbers in this assay, from the lowest: compounds 4, 3, 1 and 2 (each within the scatter of the next).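

For the compounds shown here, the amide nitrogen had not been touched by any earlier step, and this is the first reading at that position. In this assay, methyl in place of hydrogen on an amide-type nitrogen gives a 1.5-fold lower number from compound 2 to compound 4 (0.19 log units; within the scatter), so with the rest of the structure held constant, carbamoyl can give way to methylcarbamoyl without a change that can be separated from the scatter. No supporting measurement accompanies this step, so the result stands as a bare observation on this one pair.

What remains open is whether this tolerance extends beyond a single methyl: a second methyl on the same nitrogen, an ethyl group or a longer chain, or a replacement of the amide by a carboxylic acid or a nitrile could each read differently, and the compounds shown give no step for any of them. Compound 1 carries a cyclopropyl group on the amide nitrogen but also differs on the aromatic ring, so it gives no clean reading of that nitrogen, and whether the methyl step would hold on another fluorine pattern is equally unsettled.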